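The source may report more compounds than this note shows. Statements on the series, on what has been measured and on what is new or still open speak of the compounds shown alone.

Measured compounds:
- compound 1, `Cc1nn(C)c(Oc2ccc(F)cc2)c1/C=N\CCCCCOc1cc2oc(=O)cc(C)c2cc1Cl`: 22100 nM
- compound 2, `Cc1nn(C)c(Oc2ccc(Br)cc2)c1/C=N\CCCCCOc1cc2oc(=O)cc(C)c2cc1Cl`: "not determined" (no result reported)
- compound 3, `Cc1nn(C)c(Oc2ccc(F)cc2)c1/C=N\CCCCCCOc1cc2oc(=O)cc(C)c2cc1Cl`: 13500 nM

Three compounds share one core and differ only in the linking chain and in the halogen on the phenoxy ring. In a functional assay on SMMC-7721 cells (Homo sapiens) for antiproliferative activity, read by MTT assay, with a stated time of 72 h (on this read-out higher numbers stand for weaker inhibition and lower numbers for stronger inhibition), compound 1 gives 22100 nM. For compound 2 the outcome in this assay is "not determined" (no result reported), so it adds no number to compare. In this assay compound 3 gives 13500 nM. Of the two numbers available, compound 3 has the lower one, but its gap to compound 1 lies within the usual scatter, so the two cannot be told apart on this evidence.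

The next compound, compound 4, `Cc1nn(C)c(Oc2ccc(I)cc2)c1/C=N\CCCCCCOc1cc2oc(=O)cc(C)c2cc1Cl`, keeps the chain of compound 3 and changes only the halogen: iodo in place of fluoro on an aromatic carbon. For the measured compounds named here, no pair of measured compounds shows this same change, so there is no measured step to lean on. With nothing in the data pointing to a large effect, the expectation for the step from compound 3 to compound 4 in this assay is a small move, if any, not clearly beyond the scatter: a 1.4-fold lower number from compound 3 to compound 4 (0.13 log units; within the scatter) is the estimated size. Compound 4 is therefore expected to give about 10000 nM in this assay, within a range from 4000 nM to 25000 nM.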

Compound 4, half-maximal inhibitory concentration: 13300 nM
Estimate against measurement, compound 4: 1.3-fold (0.12 log units) below, and the stated range covers the measured number.
By their numbers in this assay, from the lowest: compounds 4, 3 and 1 (each within the scatter of the next).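

In this assay, for the compounds shown here, the change of fluoro to iodo on the aromatic carbon para to a large group gives a 1.0-fold lower number from compound 3 to compound 4 (0.01 log units; within the scatter), the first reading of a change at this position, as compound 2 offers no number. Fluoro and iodo, each a single heavy atom with no hydrogen-bond donors or acceptors, cannot be told apart here, so with the chain of compound 3 held fixed, this exchange of halogens leaves no visible mark on the read-out. Nothing measured here bears on why the two halogens read alike.

The compounds shown leave open whether this ring carbon would respond to a group other than a halogen, such as a methoxy group, an amine or a carboxylic acid. They also leave open whether fluoro and iodo would read alike on the chain of compound 1, and what a longer chain than that of compound 3 would do with either halogen in place.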